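Moving the Thiophene Link: Expected Cytotoxicity of Compound 4

A few compounds are considered here, and "the series" means these few. Any claim that something is new, unique, unknown or untested is made for them only; others in the source may bear on it.

Compound 1 `CC(C)n1ncc2c(C(=O)Nc3ccccn3)cc(-c3ccsc3)nc21`: 25000 nM
Compound 2 `CC(C)n1ncc2c(C(=O)Nc3ccc(F)cc3)cc(-c3ccsc3)nc21`: > 200000 nM (a limit)
Compound 3 `CC(C)n1ncc2c(C(=O)Nc3cccc(S(N)(=O)=O)c3)cc(-c3cccs3)nc21`: 25000 nM

In an ADME assay on LLC-MK2 cells (Macaca mulatta) for cytotoxicity, read by spectrophotometry and crystal violet staining, with a stated time of 4 days (on this read-out higher numbers stand for lower toxicity in this test and lower numbers for higher toxicity in this test), compound 1 gives 25000 nM, level with compound 3 at the digits shown, within the scatter. Compound 2 reaches only the limit of > 200000 nM in this assay. Among the compounds with values here, the single measured step, an at least 8.0-fold higher number from compound 1 to compound 2 (0.90 log units; beyond the scatter), concerns the amide-type nitrogen and rests on (the limit of > 200000 nM in this assay, at which 1 of the 3 values shown sits); it does not touch the part changed here. Compound 4 `CC(C)n1ncc2c(C(=O)Nc3ccccn3)cc(-c3cccs3)nc21` differs from compound 1 by thiophen-2-yl in place of thiophen-3-yl on an aromatic carbon. No measured step covers this change, and compound 3, which also carries thiophen-2-yl, shows a value equal to compound 1 at the digits shown. Compound 4 is therefore expected near 25000 nM, between 10000 nM and 60000 nM. The step of no change at the digits printed from compound 1 to compound 4 (within the scatter) is expected to stay within the scatter.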

Compound 4, half-maximal cytotoxic concentration: > 200000 nM
Compound 4 ended at the assay's limit (the forecaster's own chance of this, stated with the estimate: 10%); middle value at least 8.0-fold (0.90 log units) from the limit.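

Moving the thiophene link alone, with the same atoms joined differently, matters in this assay: thiophen-2-yl in place of thiophen-3-yl gives an at least 8.0-fold higher number from compound 1 to compound 4 (0.90 log units; beyond the scatter). With thiophen-2-yl held in place, the amide group matters too, as pyridin-2-yl in place of 3-sulfamoylphenyl gives an at least 8.0-fold higher number from compound 3 to compound 4 (0.90 log units; beyond the scatter). Both steps end at a limit of the assay, not at a number: the limit of > 200000 nM in this assay, at which 2 of the 4 values shown sit.

From the compounds shown here alone, how far the true value of compound 4 lies past that limit remains open. Also open, going by these compounds, is whether a furan-2-yl ring or a simple amine at this position would match compound 4.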